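The source may report more compounds than this note shows. Statements on the series, on what has been measured and on what is new or still open speak of the compounds shown alone.

Among the measured compounds shown here, compound 1, `C=CCc1cc(OC)c(O[C@H](C)[C@@H](O)c2ccc(OC)c(OC)c2)c(OC)c1`, and compound 2, `C=CCc1cc(OC)c(OC(C)C(OCCOCCCC)c2ccc(O)c(OC)c2)c(OC)c1`, share a common core and differ from each other in more than one place, so no single step separates them. In an assay on HEK293 cells for agonist activity at transient receptor potential cation channel subfamily M member 8 (Homo sapiens), read by fluorescence and calcium flux, with a stated time of 5 min (on this read-out higher numbers stand for an effect only at larger amounts of compound and lower numbers for an effect already at smaller amounts), compound 1 gives > 10000 nM, which is a limit of the assay rather than a number. In this assay, for the measured compounds named here, compound 2 gives 153 nM, the only real number among the two values shown; the other value sits at the limit of > 10000 nM in this assay, at which 1 of the 2 values shown sits. Compound 3, `C=CCc1cc(OC)c(OC(C)C(OC)c2ccc(O)c(OC)c2)c(OC)c1`, has not yet been measured in this assay. It differs from compound 2 in one place: hydrogen in place of butoxymethyl on a saturated chain carbon bound to an oxygen on a saturated carbon. Going by the values given here, with no measured pair to read this change against, the expectation rests on compound 2 alone, and the step from compound 2 to compound 3 is expected to be a modest loss, a 2.6-fold higher number from compound 2 to compound 3 (0.42 log units; beyond the scatter), close to the edge of the usual scatter. Compound 3 is therefore estimated at 400 nM in this assay, with a range from 100 nM to 2000 nM.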

Compound 3, half-maximal effective concentration: 3450 nM
For compound 3 the middle estimate is 8.6-fold (0.94 log units) below the measured one; measured number above the stated range.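

In this assay, among the compounds shown here, the change from 2-butoxyethoxy to methoxy, on a saturated chain carbon bound to an oxygen on a saturated carbon, gives a 23-fold higher number from compound 2 to compound 3 (1.35 log units; beyond the scatter), so this position responds strongly to the group it carries, which the single number for compound 2 could not show. Even with only methoxy at this place, compound 3 still gives a real number, 3450 nM, and not a limit of the assay. Nothing among the data shown accounts for the size of this step.

For the compounds shown here, the single step does not tell whether the effect follows the length of the chain or the oxygen within it. Going by these compounds, how an ethoxy group, a plain hexyloxy chain or a chain ending in an amine or a carboxylic acid would read at this place remains open.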